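The source may report more compounds than this note shows. Statements on the series, on what has been measured and on what is new or still open speak of the compounds shown alone.

Compound 1 `O=C(/C(=C\c1ccc(OC(F)(F)F)cc1)S(=O)(=O)c1ccc(Br)cc1)c1ccc(Br)cc1`: 25000 nM in a functional assay on DU-145 cells (Homo sapiens) for inhibition, read by trypan blue exclusion, with a stated time of 96 h; on this read-out lower numbers stand for stronger inhibition of growth and higher numbers for weaker inhibition of growth
Compound 2 `O=C(/C(=C\c1cc(Cl)c(O)c(Cl)c1)S(=O)(=O)Cc1ccc(Br)cc1)c1ccc(Br)cc1`: 25000 nM in this assay

On these numbers compound 2 stands level with compound 1 in this assay; the two values show no difference beyond the scatter. Compound 3 `O=C(/C(=C\c1cc(Br)c(O)c(Br)c1)S(=O)(=O)Cc1ccc(Br)cc1)c1ccc(Br)cc1` differs from compound 2 by 3,5-dibromo-4-hydroxyphenyl in place of 3,5-dichloro-4-hydroxyphenyl on a double-bonded chain carbon bound to a double-bonded chain carbon. Among the compounds with values here, no measured pair in this set carries such a change, so its size has to be expected rather than read off. Compound 3 is expected to give about 25000 nM in this assay, with a range from 12000 nM to 50000 nM. The expected step is no change at the digits printed from compound 2 to compound 3 (within the scatter), nothing beyond the scatter.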

Compound 3, concentration for 50% growth inhibition: 25000 nM
Estimate against measurement, compound 3: no gap at the digits printed, and the stated range covers the measured number.
By their numbers in this assay, from the lowest: compounds 1, 2 and 3 (each within the scatter of the next).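

In this assay, replacing 3,5-dichloro-4-hydroxyphenyl with 3,5-dibromo-4-hydroxyphenyl gives no change at the digits printed from compound 2 to compound 3 (within the scatter) at this place, on a double-bonded chain carbon bound to a double-bonded chain carbon. Within the data shown here, this is the first comparison here in which only one place differs, and on this read-out the chlorine and bromine forms cannot be told apart. Nothing available bears on the reason for this result.

The compounds shown leave open whether an amine or a carboxylic acid in place of these halogens would shift the value in this assay. From the compounds shown here alone, compound 1 differs from compound 2 in more than one place, so the effect of each of those differences also remains open.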